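Sulfamoyl to methylsulfonyl step in the shared series

A few compounds are considered here, and "the series" means these few. Any claim that something is new, unique, unknown or untested is made for them only; others in the source may bear on it.

Measured so far:
compound 1, `CS(=O)(=O)c1ccc(Nc2ncc(F)c(Nc3nc4ccccc4s3)n2)cc1`, in a functional assay on MDA-MB-231 cells (Homo sapiens) for antiproliferative activity, read by MTT assay, with a stated time of 48 h (on this read-out lower numbers stand for stronger inhibition and higher numbers for weaker inhibition), compound 1 gives 4980 nM
compound 2, `Cc1ccc2nc(Nc3nc(Nc4ccc(S(N)(=O)=O)cc4)ncc3F)sc2c1`, in this assay compound 2 gives 6390 nM
compound 3, `NS(=O)(=O)c1ccc(Nc2ncc(F)c(Nc3nc4ccccc4s3)n2)cc1`, in this assay compound 3 gives 22600 nM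

Three compounds carry the same sulfonyl-bearing aryl amine on one side and differ in two places. Compound 1 differs from compound 3 by methyl in place of amino on a sulfonyl sulfur; this gave a 4.5-fold lower number from compound 3 to compound 1 (0.66 log units; beyond the scatter). Compound 2 differs from compound 3 in the core, by methyl in place of hydrogen on an aromatic carbon; the corresponding step reads a 3.5-fold higher number from compound 2 to compound 3 (0.55 log units; beyond the scatter). Compound 1 and compound 2 thus each gain on compound 3 by a different route, and their own two numbers lie within the scatter of each other, so no order between compound 1 and compound 2 is claimed.

Compound 4, `Cc1ccc2nc(Nc3nc(Nc4ccc(S(C)(=O)=O)cc4)ncc3F)sc2c1`, is not yet measured in this assay. It combines both routes: relative to compound 2 it carries methyl in place of amino on a sulfonyl sulfur, and the place is the same word for word as in the change from compound 3 to compound 1, so this is the same change, seen once before. If the gain it brought from compound 3 to compound 1 carries over onto the core of compound 2, compound 4 is expected to land at about a 3.6-fold lower number from compound 2 to compound 4 (0.55 log units; beyond the scatter), which rests on a 4.5-fold lower number from compound 3 to compound 1 (0.66 log units; beyond the scatter) and on compound 2 at 6390 nM. Whether the two gains add fully is not shown by any pair here, so the range is kept wide. Compound 4 is estimated at 1800 nM, between 600 nM and 5000 nM.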

Compound 4, half-maximal inhibitory concentration: 14300 nM
The estimate for compound 4 lay 7.9-fold (0.90 log units) below the measured number; the measured number lies above the stated range.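

On the core of compound 2, the sulfamoyl to methylsulfonyl change gives a 2.2-fold higher number from compound 2 to compound 4 (0.35 log units; beyond the scatter), so in this assay the gain seen on the core of compound 3 does not carry over and the direction of the step is reversed: the same change on two cores in this assay, a 4.5-fold lower number (0.66 log units; beyond the scatter) from compound 3 to compound 1 and a 2.2-fold higher number (0.35 log units; beyond the scatter) from compound 2 to compound 4, 10-fold (1.01 log units) apart, beyond the scatter of two such steps

Read from the other side, the methyl on the aromatic carbon gives a 2.9-fold higher number from compound 1 to compound 4 (0.46 log units; beyond the scatter) among the methylsulfonyl compounds, whereas it lowers the number among the sulfamoyl compounds, so this change does not transfer between the two sulfonyl groups either: the same change on two cores in this assay, a 3.5-fold higher number (0.55 log units; beyond the scatter) from compound 2 to compound 3 and a 2.9-fold lower number (0.46 log units; beyond the scatter) from compound 4 to compound 1, 10-fold (1.01 log units) apart, beyond the scatter of two such steps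

Among the compounds shown here, the four compounds therefore show that the two changes do not add and that a step read on one core cannot be assumed on the other, but they do not show why, and with only two cores and one read-out they set no general rule for either change.

The compounds shown leave open how other groups on the sulfonyl sulfur, such as ethyl or a dimethylamino group, would behave on these two cores. They also leave open whether replacing the methyl on the aromatic carbon with chlorine or methoxy would give the same reversal between the sulfamoyl and methylsulfonyl compounds.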